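A few compounds are considered here, and "the series" means these few. Any claim that something is new, unique, unknown or untested is made for them only; others in the source may bear on it.

The series shares one core and was tested in a physicochemical assay for solubility, using the shake flask method, in phosphate buffer, measured as kinetic solubility, with a stated time of 20 h, at pH 6.5; a higher number here means a more soluble compound, a lower number a less soluble compound. In that assay, compound 1 `Fc1ccc(-c2nc3cnc(Nc4cc(C(F)(F)F)ccn4)cc3[nH]2)cc1F` gives < 5000 nM, which is a limit of the assay and not a number. Compound 2 `FC(F)(F)c1cccc(-c2nc3cnc(Nc4cc(-c5nnn[nH]5)ccn4)cc3[nH]2)c1` gives < 5000 nM, again only a limit. For the measured compounds named here, compound 3 `FC1(F)CCC(c2nc3cnc(Nc4ccc(C(F)(F)F)cn4)cc3[nH]2)C1` is the only compound here with an actual number, a solubility of 120000 nM.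

Compound 4 `FC1(F)CCC(c2nc3cnc(Nc4ccc(C(F)(F)F)cn4)cc3[nH]2)CC1` has yet to be measured. It differs from compound 3 in a single place: 4,4-difluorocyclohexyl stands in place of 3,3-difluorocyclopentyl on an aromatic carbon of the five-membered aromatic ring with 2 nitrogen (4,4-difluorocyclohexyl in place of 3,3-difluorocyclopentyl on an aromatic carbon). The five-membered non-aromatic ring of carbon thus becomes a six-membered one, and the counted hydrogen-bond donors and acceptors do not differ. Going by the values given here, no measured pair in this small set shows what such a swap does, so the expectation rests on compound 3 at 120000 nM as its only anchor. In this assay, the expected change is small and downward, and it is estimated to stay within the usual scatter: a 1.7-fold lower number from compound 3 to compound 4 (0.23 log units; within the scatter). The estimated solubility of compound 4 is 70000 nM, with an expected range from 15000 nM to 180000 nM.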

Compound 4, solubility: 99000 nM
Compound 4: the middle estimate sits 1.4-fold (0.15 log units) below what was measured; measured number inside the range.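

At this place, on an aromatic carbon of a five-membered aromatic ring with 2 nitrogen, the swap of 3,3-difluorocyclopentyl for 4,4-difluorocyclohexyl can now be read directly in this assay: a 1.2-fold lower number from compound 3 to compound 4 (0.08 log units; within the scatter). For the compounds shown here, this is the first step in the set that can be read, and it shows that enlarging the five-membered non-aromatic ring of carbon to a six-membered one, with no difference in counted hydrogen-bond donors or acceptors, leaves two values that the usual scatter cannot separate. Going by these compounds alone, with compound 4 at 99000 nM, compound 3 is also no longer the only compound with an actual number.

Compound 1 and compound 2 differ from compound 3 in more than one place and each gives only a limit of the assay, so neither says anything about this position: the limit of < 5000 nM in this assay, at which 2 of the 4 values shown sit. Whether a cyclohexyl ring without fluorine, a ring carrying an amine, or a carboxylic acid at this place would give a number in the same range stays open, as the compounds shown hold only these two difluorinated rings there with an actual number.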